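The source may hold more compounds than are shown below. What is called first, only, known or untested is meant among the compounds shown, and "the series" means these compounds.

In a physicochemical assay for lipophilicity, read by LC-MS, using the shake flask method, in phosphate buffer, measured as octanol-water partition, with a stated time of 2 h, at pH 7.4 (on this read-out higher numbers stand for higher lipophilicity and lower numbers for lower lipophilicity), the measured compounds stand as follows:
Compound 1 `O=C(O)c1cncc(-n2cc(CO[C@H]3O[C@H](CO)[C@@H](O)[C@H](O)[C@@H]3O)nn2)c1` gives "not determined" (no result reported)
Compound 2 `COc1ccc(Cn2cc(CO[C@H]3O[C@H](CO)[C@@H](O)[C@H](O)[C@@H]3O)nn2)cc1` gives -0.4
Compound 3 `O=[N+]([O-])c1ccc(-n2cc(CO[C@H]3O[C@H](CO)[C@@H](O)[C@H](O)[C@@H]3O)nn2)cc1` gives -0.16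

All three carry the shared core and differ in the group on an aromatic nitrogen. Compound 1 has no number to compare. For the measured compounds named here, compound 2 stands at -0.4 and has compound 3 as its only neighbour with a number.

Compound 4 `OC[C@H]1O[C@H](OCc2cn(-c3cccc(F)c3)nn2)[C@@H](O)[C@@H](O)[C@@H]1O` has not been measured yet. The change from compound 2 to compound 4 is 3-fluorophenyl in place of 4-methoxybenzyl on an aromatic nitrogen and, in words, 3-fluorophenyl in place of 4-methoxybenzyl on an aromatic nitrogen of a five-membered aromatic ring with 3 nitrogen.

Going by the values given here, one measured step bears on this. It also takes away 4-methoxybenzyl, with 4-nitrophenyl entering on the aromatic nitrogen. Judging by a number 0.24 log units higher from compound 2 to compound 3 (within the scatter) as the only guide, a small upward step is expected for compound 4 in this assay and none beyond the scatter. The estimated change is a number 0.25 log units higher from compound 2 to compound 4 (within the scatter) and it stays modest for that reason. Among the compounds with values here, a single step is thin evidence and 3-fluorophenyl itself has no measurement yet, so the range is kept wide. The estimate for compound 4 is -0.15 with an expected range from -0.55 to 0.25 as the likely span.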

Compound 4, distribution coefficient: 0.18
For compound 4 the middle estimate is 0.33 log units below the measured one, within the range that was stated.
By their numbers in this assay, from the lowest: compounds 2 and 3 (each within the scatter of the next); then compound 4.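

In this assay, the group on the aromatic nitrogen can shift the read-out beyond the usual scatter: 3-fluorophenyl in place of 4-methoxybenzyl gives a number 0.58 log units higher from compound 2 to compound 4 (beyond the scatter), while the earlier step with 4-nitrophenyl, a number 0.24 log units higher from compound 2 to compound 3 (within the scatter), did not show this. The new compound also separates two groups that both carry a six-membered aromatic ring of carbon only and neither of which is a benzyl: 3-fluorophenyl in place of 4-nitrophenyl gives a number 0.34 log units higher from compound 3 to compound 4 (beyond the scatter), so the identity of the ring's substituent, or its place, matters here as well as the benzyl-to-phenyl difference. No measurement shown accounts for the size or direction of these steps.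

The compounds shown cannot separate the contribution of the fluorine from that of its place on the ring, and a plain phenyl or a 4-fluorophenyl group would be needed to tell these apart. As far as these compounds go, how an amine or a longer alkyl chain on the same nitrogen would read also stays open, and compound 1, with its carboxylic acid, gives "not determined" (no result reported).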